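The source may report more compounds than this note shows. Statements on the series, on what has been measured and on what is new or still open speak of the compounds shown alone.

Two measured compounds share one core and differ only in the group at the far end of the benzyl ether. Compound 1 `Cc1ccc(NC(=S)NC(=O)c2ccc(OCc3ccccc3)cc2)cc1-c1nc2ccccc2[nH]1` carries an unsubstituted phenyl there; in a functional assay on MNK45 cells (Homo sapiens) for inhibition, read by MTT assay, with a stated time of 48 h (on this read-out lower numbers stand for stronger inhibition and higher numbers for weaker inhibition), compound 1 gives 57800 nM. Compound 2 `Cc1ccc(NC(=S)NC(=O)c2ccc(OCc3cccc(Cl)c3Cl)cc2)cc1-c1nc2ccccc2[nH]1` carries a 2,3-dichlorophenyl instead. In this assay compound 2 reaches only the limit of > 100000 nM, so no number is known for it, only that it sits at the limit of > 100000 nM in this assay, at which 1 of the 2 values shown sits. For the measured compounds named here, the one step between them, an at least 1.7-fold higher number from compound 1 to compound 2 (0.23 log units; that floor lies within the scatter), therefore cannot be sized beyond its floor.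

Compound 3 `Cc1ccc(NC(=S)NC(=O)c2ccc(OCc3ccccc3Cl)cc2)cc1-c1nc2ccccc2[nH]1` is the next member. Its difference from compound 2 is hydrogen in place of chloro on an aromatic carbon; cut one bond further out it reads 2,3-dichlorophenyl to 2-chlorophenyl. Going by the values given here, only the step from compound 1 to compound 2 bears on this change, and it moved in the direction of weaker inhibition, partly reversed here. The expected step is an at least 1.1-fold lower number from compound 2 to compound 3 (0.04 log units; that floor lies within the scatter), a small return toward compound 1, likely still within the scatter. For compound 3 the expected value in this assay is 90000 nM, within 40000 nM to 200000 nM, with a fair chance that only a limit is reported.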

Compound 3, half-maximal inhibitory concentration: 51400 nM
For compound 3 the middle estimate is 1.8-fold (0.24 log units) above the measured one; the measured number falls inside the stated range.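

For the compounds shown here, the 2-chlorophenyl gives the first comparison at this end of the molecule between two real numbers, and in this assay it reads a 1.1-fold lower number from compound 1 to compound 3 (0.05 log units; within the scatter) so one chloro on the ring shows no measurable change against the plain phenyl. Going the other way, taking away the second chloro reads an at least 1.9-fold lower number from compound 2 to compound 3 (0.28 log units; that floor lies within the scatter) and so even the floor of this step does not establish a real difference between the 2,3-dichlorophenyl and the 2-chlorophenyl. Compound 2 stands only at a limit, which keeps the true size of that step unknown: the limit of > 100000 nM in this assay, at which 1 of the 3 values shown sits.

Whether the second chloro truly weakens inhibition therefore stays unsettled, as no actual number exists for compound 2. Going by these compounds, what a different group on this ring would do also stays open, for instance a methoxy group or an amine in place of the chloro, and so does whether any such group could bring the number clearly below that of compound 1.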